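The source may report more compounds than this note shows. Statements on the series, on what has been measured and on what is new or still open speak of the compounds shown alone.

Working notes on the series in a functional assay on IGROV-1 cells (Homo sapiens) for inhibition, read by sulforhodamine B assay, with a stated time of 48 h; on this read-out lower numbers stand for higher toxicity in this test and higher numbers for lower toxicity in this test.

Compound 1 `COc1ccc(-c2cc(/C=C/C(=O)c3ccc(N)cc3)[nH]n2)cc1` gives 43300 nM. Compound 3 `COc1ccc(-c2cc(/C=C/C(=O)c3ccc(N)cc3)[nH]n2)cc1OC` gives 73000 nM. Between them stands one change, (methoxy in place of hydrogen on an aromatic carbon), and the step of a 1.7-fold higher number from compound 1 to compound 3 (0.23 log units; within the scatter). Compound 2 `COc1ccc(C(=O)/C=C/c2cc(-c3cc(OC)c(OC)c(OC)c3)n[nH]2)cc1OC` gives 6480 nM, the lowest of the three numbers; how its core differs from that of compound 1 is not broken down here.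

Compound 4 `COc1cc(C(=O)/C=C/c2cc(-c3cc(OC)c(OC)c(OC)c3)n[nH]2)cc(OC)c1OC` is not yet measured. It carries the same kind of change from compound 2 as compound 3 does from compound 1, (methoxy in place of hydrogen on an aromatic carbon); the surroundings differ in that the new group is also meta to a methoxy group in compound 4. Within the data shown here, the only reference for this change is the step from compound 1 to compound 3, which stayed within the scatter, so for compound 4 a comparably small step a 1.4-fold higher number from compound 2 to compound 4 (0.14 log units; within the scatter) is expected, resting on compound 2 at 6480 nM. Compound 4 is estimated at 9000 nM, between 4000 nM and 25000 nM.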

Compound 4, concentration lethal to 50% of the cells: 33100 nM
Estimate against measurement, compound 4: 3.7-fold (0.57 log units) below, and the stated range ends below it.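

In this assay methoxy in place of hydrogen on an aromatic carbon gives a 5.1-fold higher number from compound 2 to compound 4 (0.71 log units; beyond the scatter), so the size of this step does not carry over from one core to the other: the same change on two cores in this assay, a 1.7-fold higher number (0.23 log units; within the scatter) from compound 1 to compound 3 and a 5.1-fold higher number (0.71 log units; beyond the scatter) from compound 2 to compound 4, 3.0-fold (0.48 log units) apart, beyond the scatter of two such steps

Among these compounds, the comparison rests on only two pairs, which shows that the step can depend on its surroundings but not which feature of them matters. The two cores differ in more than one place, and in compound 4 the new methoxy also stands ortho to a methoxy group, so these pairs cannot separate those differences.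

On these data alone, it remains open whether a hydroxy group or a fluorine atom at this place would give a comparable step on either core.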